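The compounds below may be only part of what the source reports. "The series", "measured", "known", "first", "only" and "open" are said of these compounds alone.

Measured compounds:
- compound 1 `CC(C)=CCC[C@]1(C)/C=C/[C@@H](OC(=O)C=C(C)C)[C@](C)(O)/C=C/C(=O)/C(CN(C)C)=C\C1`: 690 nM
- compound 2 `CO/N=C/C1=C/C[C@](C)(CCC=C(C)C)/C=C/[C@@H](OC(=O)C=C(C)C)[C@](C)(O)/C=C/C1=O`: 2510 nM

In a functional assay on MCF7 cells (Homo sapiens) for antiproliferative activity, read by MTT assay, with a stated time of 48 h (a higher number here means a weaker inhibitor, a lower number a stronger inhibitor), compound 2 gives 2510 nM, the higher of the two numbers, which makes it the weaker inhibitor of the pair. Still unmeasured is compound 3 `CC(C)=CCC[C@]1(C)/C=C/[C@@H](OC(=O)C=C(C)C)[C@](C)(O)/C=C/C(=O)/C(C(=O)N2CCCC2)=C\C1`, which differs from compound 2 as follows: a group of 7 heavy atoms (5 carbon, 1 nitrogen, 1 oxygen; one five-membered non-aromatic ring with 1 hetero atom) in place of a group of 4 heavy atoms (2 carbon, 1 nitrogen, 1 oxygen; no ring), on a double-bonded ring carbon. The new group, (pyrrolidin-1-yl)carbonyl, brings a five-membered non-aromatic ring that neither measured compound carries on that carbon.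

Going by the values given here, only one measured step bears on this change: a 3.6-fold higher number from compound 1 to compound 2 (0.56 log units; beyond the scatter). It falls at the same double-bonded ring carbon, and it is modest but beyond the scatter. Among the compounds with values here, no measured compound shows what a ring-bearing group does here, so the direction remains uncertain. With compound 1 at 690 nM as the only lower reference, a modest move towards lower numbers is expected, no larger than that measured step. The expected change is a 1.7-fold lower number from compound 2 to compound 3 (0.22 log units; within the scatter). For compound 3, the estimated value is 1500 nM, with an expected range of 500 nM to 4500 nM.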

Compound 3, half-maximal inhibitory concentration: 17200 nM
Compound 3: middle estimate off by 11-fold (1.06 log units), on the low side; measured number above the stated range.
By their numbers in this assay, from the lowest: compound 1; then compound 2; then compound 3.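

In this assay, going by these compounds alone, the double-bonded ring carbon proves more sensitive to change than the first pair of compounds could show: (pyrrolidin-1-yl)carbonyl gives a 6.9-fold higher number from compound 2 to compound 3 (0.84 log units; beyond the scatter), and in place of the (dimethylamino)methyl group it gives a 25-fold higher number from compound 1 to compound 3 (1.40 log units; beyond the scatter), a large step. Within the data shown here, the first group at this carbon to bring a ring therefore moves the number upwards, towards a weaker inhibitor, and compound 3 ranks last of the three, behind both groups without a ring. The data offer no measured explanation for this loss of activity.

The compounds shown leave open whether the pyrrolidine ring or the carbonyl joined directly to the ring carbon goes with the higher number, a question that a (dimethylamino)carbonyl group and a (pyrrolidin-1-yl)methyl group at the same carbon would separate. Also open, as far as these compounds go, is how a primary amine, a carboxylic acid or a longer chain ending in a dimethylamino group would compare with the (dimethylamino)methyl group of compound 1.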